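The source may report more compounds than this note shows. Statements on the series, on what has been measured and on what is new or still open speak of the compounds shown alone.

Measured compounds, values from a functional assay on HeLa cells (Homo sapiens) for cytotoxicity, read by MTT assay, with a stated time of 24 h; on this read-out lower numbers stand for stronger inhibition and higher numbers for weaker inhibition

compound 1 `COc1ccc(/C=C(\C#N)C(=O)N/N=C(\C)c2c(O)c3ccc(O)cc3oc2=O)cc1` gives 7850 nM
compound 2 `C/C(=N\NC(=O)/C(C#N)=C/c1ccc(N(C)C)cc1)c1c(O)c2ccc(O)cc2oc1=O` gives 5140 nM

Compound 2 sits within the scatter of compound 1, so the two numbers cannot be ranked. For the measured compounds named here, compound 3 `C/C(=N\NC(=O)/C(C#N)=C/c1cccc([N+](=O)[O-])c1)c1c(O)c2ccc(O)cc2oc1=O` differs from compound 2 by 3-nitrophenyl in place of 4-(dimethylamino)phenyl on a double-bonded chain carbon bound to a double-bonded chain carbon as its single change, 3-nitrophenyl in place of 4-(dimethylamino)phenyl on a double-bonded chain carbon bound to a double-bonded chain carbon. Going by the values given here, one measured step bears on this, a 1.5-fold lower number from compound 1 to compound 2 (0.18 log units; within the scatter) for a swap of one group on the aromatic ring. Among the compounds with values here, that step is small, but no measured compound carries 3-nitrophenyl, so the data give no direction. No step beyond the scatter is expected in this assay for now. The estimated step is a 1.2-fold higher number from compound 2 to compound 3 (0.07 log units; within the scatter) and is expected to remain within the scatter. Compound 3 is estimated at 6000 nM in this assay with a range of 2500 nM to 14000 nM expected for it.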

Compound 3, half-maximal inhibitory concentration: 24600 nM
For compound 3 the middle estimate is 4.1-fold (0.61 log units) below the measured one; the measured number lies above the stated range.
By their numbers in this assay, from the lowest: compounds 2 and 1 (each within the scatter of the next); then compound 3.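

In this assay the aryl group on a double-bonded chain carbon bound to a double-bonded chain carbon can shift the number beyond the scatter: 3-nitrophenyl gives a 4.8-fold higher number from compound 2 to compound 3 (0.68 log units; beyond the scatter) and a 3.1-fold higher number from compound 1 to compound 3 (0.50 log units; beyond the scatter), whereas the swap of 4-methoxyphenyl for 4-(dimethylamino)phenyl gave only a 1.5-fold lower number from compound 1 to compound 2 (0.18 log units; within the scatter). This place is therefore not indifferent to the group it carries, and compound 3 stands apart from both compounds with a 4-substituted phenyl group. Nothing measured here accounts for the shift.

The nitro group and the change from a 4-substituted to a 3-substituted phenyl group arrive together, so the two remain unseparated. A 4-nitrophenyl or 3-methoxyphenyl group would test each alone, and an unsubstituted phenyl group would give the baseline for all three compounds.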